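The source may report more compounds than this note shows. Statements on the series, on what has been measured and on what is new or still open speak of the compounds shown alone.

Three measured compounds share a core: compound 1 `Cc1n[nH]c(C(=O)O)c1Cc1cccc(-c2ccc(C#N)cc2)c1`, compound 2 `Cc1n[nH]c(C(=O)O)c1Cc1cccc(-c2ccc(C(=O)O)cc2)c1` and compound 3 `Cc1n[nH]c(C(=O)O)c1Cc1cccc(C(=O)O)c1`. Compound 4 `Cc1n[nH]c(C(=O)O)c1Cc1cccc(C#N)c1` has not yet been measured. In an assay on isolated protein for inhibition of 2-Hydroxyacid oxidase 2 (Homo sapiens), tested at 10 uM (a higher number here means a stronger effect of the compound at the concentration tested, a lower number a weaker effect), compound 1 gives 46%, compound 2 gives 15% and compound 3 gives 0%. The step of a number 31 percentage points higher from compound 2 to compound 1 (beyond the scatter) came from the change (cyano in place of carboxy on an aromatic carbon). The step of a number 46 percentage points lower from compound 1 to compound 3 (beyond the scatter) shows how much the larger group matters. The difference between the core of compound 2 and that of compound 3 is not broken down here. Compound 4 arises from compound 3 by cyano in place of carboxy on an aromatic carbon, the same kind of change as before, though its place differs: para to a large group there, meta to a large group here. Compound 4 is expected to give 12%, somewhere between 0% and 30%. The expected step of a number 12 percentage points higher from compound 3 to compound 4 (beyond the scatter) is smaller than the earlier one because compound 3 gives 0%.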

Compound 4, a percentage reported as inhibition, at one concentration (the size of the read-out at that concentration, not a potency): 19%
Estimate against measurement, compound 4: 7 percentage points below; the range from low to high includes it.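

In this assay, within the data shown here, cyano in place of carboxy again raises the number, a number 19 percentage points higher from compound 3 to compound 4 (beyond the scatter), and the size of this step does not differ from the one seen on the other core: the same change on two cores in this assay, a number 31 percentage points higher (beyond the scatter) from compound 2 to compound 1 and a number 19 percentage points higher (beyond the scatter) from compound 3 to compound 4, 12 percentage points apart, within the scatter of two such steps With only two pairs, this shows that the change carried over between these two cores, but not that it would do so on others, nor why it helps. Replacing the 4-cyanophenyl group with cyano gives a number 27 percentage points lower from compound 1 to compound 4 (beyond the scatter), so the larger group still matters when cyano replaces it.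

As far as these compounds go, it remains open whether a primary amide or a methyl ester in the same place would match cyano. Whether a halogen such as chlorine would do so is also unknown.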